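A few compounds are considered here, and "the series" means these few. Any claim that something is new, unique, unknown or untested is made for them only; others in the source may bear on it.

Measured so far in an ADME assay on Vero cells (Chlorocebus sabaeus) for cytotoxicity, read by neutral red uptake, tested at 394 ug/mL; a lower number here means a stronger effect, a higher number a weaker effect of the compound at the concentration tested:
Compound 1 `COc1ccc(C2SCC(=O)N2CCN2CCCCC2)cc1` gives 73%.
Compound 2 `O=C1CSC(c2ccc(O)cc2)N1CCN1CCCCC1` gives 76%.
Compound 3 `O=C1CSC(c2ccc(F)cc2)N1CCN1CCCCC1` gives 52%.

Compound 2 and compound 1 sit together: the step of a number 3 percentage points higher from compound 1 to compound 2 (within the scatter) is within the scatter, so the two cannot be told apart on these numbers. Compound 3 stands apart from both, lower by a number 21 percentage points lower from compound 1 to compound 3 (beyond the scatter) and by a number 24 percentage points lower from compound 2 to compound 3 (beyond the scatter).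

The next compound, compound 4 `O=C1CSC(c2ccccc2Cl)N1CCN1CCCCC1`, has not yet been measured in this assay. Compared with compound 2 the change is 2-chlorophenyl in place of 4-hydroxyphenyl on a saturated ring carbon.

Among the measured compounds shown here, two measured steps bear on it. In both, the group on the aromatic ring that carries an oxygen was exchanged for one without it, and in both the number fell by a modest amount: a number 21 percentage points lower from compound 1 to compound 3 (beyond the scatter) and a number 24 percentage points lower from compound 2 to compound 3 (beyond the scatter). For the measured compounds named here, the change to compound 4 again removes the oxygen-bearing group, but what enters, 2-chlorophenyl, has no measured counterpart here, so the expectation rests on the two steps to compound 3 alone.

For compound 4 a modest fall is expected, about a number 20 percentage points lower from compound 2 to compound 4 (beyond the scatter). Compound 4 is estimated at 56% in this assay. For compound 4 the range is expected to run from 40% to 72%.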

Compound 4, a percentage reported as activity, at one concentration (the size of the read-out at that concentration, not a potency): 31%
For compound 4 the middle estimate is 25 percentage points above the measured one; measured number outside the range, below it.
By their numbers in this assay, from the lowest: compound 4; then compound 3; then compounds 1 and 2 (each within the scatter of the next).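

Among the compounds shown here, the earlier compounds showed only that groups on the aromatic ring could shift the number by a modest amount, and compound 4 shows that the aryl group on this saturated ring carbon can shift it much further. In this assay the exchange of 4-hydroxyphenyl for 2-chlorophenyl gives a large step (a number 45 percentage points lower from compound 2 to compound 4 (beyond the scatter)), so a lower number, meaning a stronger effect on the cells, is reached here than with any earlier compound. Losing the oxygen-bearing group also does not settle the outcome, since the two aryl groups without oxygen are themselves separated by a modest step (a number 21 percentage points lower from compound 3 to compound 4 (beyond the scatter)).

The step from 4-fluorophenyl to 2-chlorophenyl changes both the halogen and its place on the ring, so these compounds cannot show which of the two matters, and 4-chlorophenyl or 2-fluorophenyl would be the direct tests. Nothing measured here explains why the effect grows, and no independent data on these compounds bear on the cause.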